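This account rests on a few compounds, and the source may have more. Where it says the series, first, only, none or still open, it means among the compounds named here.

Measured in an assay on cells for activation of probable G-protein coupled receptor 34 (Mus musculus), with a stated time of 1 h; a lower number here means a smaller maximal response, a higher number a larger maximal response:
compound 1, `N[C@@H](COP(=O)(O)OCCCOC(=O)CCc1ccccc1OCc1cccc(OC2CCCCC2)c1)C(=O)O`: 0.11
compound 2, `N[C@@H](COP(=O)(O)OCCCOC(=O)CCc1ccccc1OCc1cccc(Oc2cccc(Cl)c2)c1)C(=O)O`: 0.53
compound 3, `N[C@@H](COP(=O)(O)OCCCOC(=O)CCc1ccccc1OCc1cccc(Oc2ccc(Cl)cc2)c1)C(=O)O`: 0.76

Among these three compounds, compound 1 stands lowest in the assay. The nearest value is that of compound 2, a number 0.42 higher from compound 1 to compound 2 (beyond the scatter), and the furthest that of compound 3, a number 0.65 higher from compound 1 to compound 3 (beyond the scatter). Between the two chlorophenyl analogues the step is a number 0.23 higher from compound 2 to compound 3 (beyond the scatter).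

Compound 4, `CC(C)(C)c1ccc(Oc2cccc(COc3ccccc3CCC(=O)OCCCOP(=O)(O)OC[C@H](N)C(=O)O)c2)cc1`, has not yet been measured in the assay. Relative to compound 1 the change is 4-(tert-butyl)phenyl in place of cyclohexyl on an oxygen on an aromatic ring

Both measured steps from compound 1 bear on this change: each puts a chlorophenyl in place of the cyclohexyl on the same oxygen, and each raises the maximal response well beyond the scatter, a number 0.42 higher from compound 1 to compound 2 (beyond the scatter) and a number 0.65 higher from compound 1 to compound 3 (beyond the scatter). Compound 4 likewise carries an aromatic ring on that oxygen in place of the cyclohexyl, so a large upward step is expected in the assay, a number 0.54 higher from compound 1 to compound 4 (beyond the scatter). Whether 4-(tert-butyl)phenyl will land nearer the value of compound 3 or that of compound 2 cannot be told from these three compounds, which widens the range. The estimate for compound 4 in the assay is 0.65, expected to fall between 0.4 and 0.9.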

Compound 4, intrinsic activity: the largest response reached, as a fraction of the reference agonist's: 0.079
Compound 4: the middle estimate sits 0.57 above what was measured, and the stated range ends above it.
By their numbers in this assay, from the lowest: compounds 4 and 1 (each within the scatter of the next); then compound 2; then compound 3.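

In this assay, an aromatic ring on this oxygen does not by itself bring the higher maximal response seen with the chlorophenyl analogues: a number 0.031 lower from compound 1 to compound 4 (within the scatter), leaving 4-(tert-butyl)phenyl and cyclohexyl indistinguishable in this read-out. The group carried on the aromatic ring matters as well, since tert-butyl in place of chloro on the same aromatic carbon gives a number 0.68 lower from compound 3 to compound 4 (beyond the scatter), and the change from 3-chlorophenyl to 4-(tert-butyl)phenyl also gives a large fall, a number 0.45 lower from compound 2 to compound 4 (beyond the scatter); the earlier rise on replacing cyclohexyl therefore holds for the two chlorophenyl groups and does not extend to every aryl group on this oxygen. Nothing available accounts for this loss of response.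

Open, from the compounds shown here alone, is how the response behaves with unsubstituted phenyl on this oxygen, which would separate the contribution of the ring from that of chloro or tert-butyl. Equally open, going by these compounds, is whether 4-methylphenyl or 4-isopropylphenyl stays close to compound 3 or to compound 4 in this assay.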